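Swapping a sugar-like ring for benzyl on the core

The source may report more compounds than this note shows. Statements on the series, on what has been measured and on what is new or still open speak of the compounds shown alone.

Measured so far in a functional assay (B cells) with Mus musculus as the target; on this read-out lower numbers stand for an effect already at smaller amounts and higher numbers for an effect only at larger amounts of compound:
- compound 1, `C=CCn1c(=O)n([C@H]2CO[C@@H](CO)C2)c2nc(N)nc(O)c21`, gives 83 uM
- compound 2, `Nc1nc(O)c2c(n1)n(C1OC(CO)[C@@H](O)[C@H]1O)c(=O)n2CC(O)CSc1ccccc1`, gives 142 uM
- compound 3, `Nc1nc(O)c2c(n1)n(C1OC(CO)[C@@H](O)[C@H]1O)c(=O)n2Cc1ccc(OCc2ccccc2)cc1`, gives 8 uM

Compound 1 stands second highest of the three numbers. Its nearest neighbour is compound 2, whose number lies within the scatter of repeated measurements, so the two cannot be told apart. Compound 3 lies furthest away, with a number far enough below that of compound 1 to count as a real difference, and it is the only one of the three that carries an aromatic ring with a second aromatic ring attached through oxygen.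

The new compound 4, `C=CCn1c(=O)n(Cc2ccccc2)c2nc(N)nc(O)c21`, differs from compound 1 in one place: a group of 7 heavy atoms (7 carbon; one six-membered aromatic ring of carbon only) in place of a group of 7 heavy atoms (5 carbon, 2 oxygen; one five-membered non-aromatic ring with 1 hetero atom), on an aromatic nitrogen

Among the compounds with values here, no pair of measured compounds differs in exactly this way, so there is no measured step to lean on. The change removes the only hydrogen-bond donor outside the shared core and puts a plain benzyl in its place. Compound 4 is expected to give about 60 uM in this assay, with a likely range from 15 uM to 250 uM. The step from compound 1 to compound 4 is expected to be a 1.4-fold lower number from compound 1 to compound 4 (0.14 log units; within the scatter), that is, no change beyond the scatter in either direction.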

Compound 4, concentration for half-maximal effect: 5 uM
Beside the measured number, compound 4's estimate is 12-fold (1.08 log units) above it; the measured number lies below the stated range.
By their numbers in this assay, from the lowest: compounds 4 and 3 (each within the scatter of the next); then compounds 1 and 2 (each within the scatter of the next).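

In this assay, the step from the five-membered non-aromatic ring to benzyl gives a 17-fold lower number from compound 1 to compound 4 (1.22 log units; beyond the scatter) and so shows that this aromatic nitrogen of the shared core responds strongly to the group it carries. The earlier compounds shown here could not show this, as no two of them differ in one place, and compound 4 now shows that a low number at this position does not require the hydrogen-bond donor, the hydrogen-bond acceptors or the defined stereocentres of the group that left. Nothing at hand explains why the number falls.

A single step cannot separate the arrival of the aromatic ring from the loss of the oxygen-bearing ring. A cyclohexylmethyl group on the same nitrogen would help to separate the two, while a benzyl carrying an amine or a carboxylic acid would test how much change the ring tolerates.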